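Pyrrolidinyl for methoxymethyl: microsomal stability notes

This account rests on a few compounds, and the source may have more. Where it says the series, first, only, none or still open, it means among the compounds named here.

Measured so far:
- compound 1 `CCCCCOC(=O)N1CCN(C(=O)[C@H](CCC(=O)O)NC(=O)c2cc(N3CCC(C(=O)N(CC)CC)CC3)nc(-c3ccccc3)n2)CC1` gives > 80% in an ADME assay on microsomes from liver (Homo sapiens) for metabolic stability; a lower number here means that less of the compound is left, a higher number that more of the compound is left
- compound 2 `CCCCCOC(=O)N1CCN(C(=O)[C@H](CCC(=O)O)NC(=O)c2cc(N3CCC(COC)CC3)nc(-c3ccccc3)n2)CC1` gives > 80% in this assay

The value of compound 1 is a limit of this assay and not a number. The value of compound 2 is likewise a limit. Because both values sit at the limit of > 80% in this assay, at which 2 of the 2 values shown sit, the step that the two limits leave unreadable from compound 1 to compound 2 cannot be read in size or direction.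

Compound 3 `CCCCCOC(=O)N1CCN(C(=O)[C@H](CCC(=O)O)NC(=O)c2cc(N3CCC(N4CCCC4)CC3)nc(-c3ccccc3)n2)CC1` differs from compound 2 by pyrrolidin-1-yl in place of methoxymethyl on a saturated ring carbon. Among the compounds with values here, the only measured step, a step that the two limits leave unreadable from compound 1 to compound 2, bears on this change but gives no readable size, so no step beyond the scatter can be predicted either way. Compound 2 stands at the limit, and compound 3 is expected to remain there in this assay, with an estimate of 85% (range 60% to 95%). The implied step that the limit leaves unreadable from compound 2 to compound 3 is expected to lie within the scatter.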

Compound 3, percent of the compound remaining: > 80%
Compound 3: a limit, no number; the forecaster's own chance of this, stated with the estimate: 70%; the middle value lies beyond the limit too.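

In this assay compound 3 gives > 80%, a limit and not a number, so no step from compound 1 or compound 2 to compound 3 can be read, because all three compounds share one limit: the limit of > 80% in this assay, at which 3 of the 3 values shown sit.

The compounds shown leave open whether diethylcarbamoyl, methoxymethyl and pyrrolidin-1-yl differ at all in this assay.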